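A few compounds are considered here, and "the series" means these few. Any claim that something is new, unique, unknown or untested is made for them only; others in the source may bear on it.

Measured so far:
compound 1, `CC(C)(C)c1ccc(-c2cc(=O)c3ccc(O)cc3o2)cc1`: 44300000 nM
compound 2, `CC(C)(C)c1ccc(-c2oc3cc(O)cc(O)c3c(=O)c2O)cc1`: 709000 nM

In a physicochemical assay, read by spectrophotometry, with a stated time of 20 min (on this read-out higher numbers stand for weaker inhibition and lower numbers for stronger inhibition), compound 2 gives 709000 nM. Compound 2 stands lowest of the two numbers; compound 1, with 44300000 nM, lies well higher, a gap beyond the scatter. For the measured compounds named here, the two structures differ in more than one place, so no single step connects them and only the two values themselves can be compared.

Compound 3, `CC(C)(C)Oc1ccc(-c2oc3cc(O)cc(O)c3c(=O)c2O)cc1`, is not yet measured in this assay. It differs from compound 2 in one place: tert-butoxy in place of tert-butyl on an aromatic carbon. Going by the values given here, nothing measured bears on this change, so there is no step to lean on. The expected step is small, a 1.3-fold higher number from compound 2 to compound 3 (0.10 log units; within the scatter), within the scatter or leaning slightly toward weaker inhibition. Compound 3 is therefore estimated at 900000 nM, with a range from 300000 nM to 3000000 nM.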

Compound 3, half-maximal inhibitory concentration: 452000 nM
Compound 3: middle estimate off by 2.0-fold (0.30 log units), on the high side; low and high end bracket the measured number.
By their numbers in this assay, from the lowest: compounds 3 and 2 (each within the scatter of the next); then compound 1.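

In this assay, this series now has its first step confined to one place: a 1.6-fold lower number from compound 2 to compound 3 (0.20 log units; within the scatter) for tert-butoxy in place of tert-butyl on an aromatic carbon, para to a large group. At this position, then, the swap adds one oxygen and one hydrogen-bond acceptor, yet the two values stay within the scatter of each other, so this pair shows no separation between the groups. Nothing available accounts for this result or gives a measured property of either group.

On these data alone, whether an amine, a carboxylic acid or a longer chain at this position would stay within the same scatter remains open. As far as these compounds go, the separate contributions of the differences between compound 1 and compound 2 also remain open, since those compounds differ in more than one place.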